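A Longer Chain on the Triazene Nitrogen

A few compounds are considered here, and "the series" means these few. Any claim that something is new, unique, unknown or untested is made for them only; others in the source may bear on it.

Of the compounds shown here, three sharing one core have been measured in a functional assay on L1210 cells (Mus musculus) for antiproliferative activity; a lower number here means a less potent compound, a higher number a more potent compound, by a factor of ten per unit of this negative logarithm. Compound 1 `CN(/N=N/c1ccc(C(N)=O)cc1)c1cccs1` gives 2.9 in this assay. Compound 2 `CN(C)/N=N/c1ccc(C(N)=O)cc1` gives 3.51, and compound 3 `CN(C)/N=N/c1ccc(NC(N)=O)cc1` gives 3.97. Compound 2 thus stands second highest of the three: it sits beyond the scatter above compound 1 and beyond the scatter below compound 3. The two measured steps are a number 0.61 log units higher from compound 1 to compound 2 (beyond the scatter) and a number 0.46 log units higher from compound 2 to compound 3 (beyond the scatter).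

Compound 4 `CCCCCCCCN(C)/N=N/c1ccc(C(N)=O)cc1` has not yet been measured. It differs from compound 2 in one place: heptyl in place of hydrogen on a saturated chain carbon bound to an amine nitrogen. Within the data shown here, only the step from compound 1 to compound 2 bears on this change, since both concern what is attached to the amine nitrogen; there, a smaller group in place of a larger one gave a modestly higher number, a number 0.61 log units higher from compound 1 to compound 2 (beyond the scatter). Growing the group again with a heptyl chain is therefore expected to lower the number modestly, by about a number 0.21 log units lower from compound 2 to compound 4 (within the scatter). Compound 4 is expected to give 3.3 in this assay, within a range of 2.7 to 3.9.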

Compound 4, logarithm of the reciprocal of the active concentration, log(1/C): 2.84
Compound 4: the middle estimate sits 0.46 log units above what was measured; the measured number falls inside the stated range.
By their numbers in this assay, from the lowest: compounds 4 and 1 (each within the scatter of the next); then compound 2; then compound 3.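

In this assay, adding heptyl on a saturated chain carbon bound to an amine nitrogen gives a number 0.67 log units lower from compound 2 to compound 4 (beyond the scatter). Among these compounds, until now the only change seen at this nitrogen involved a ring, thiophen-2-yl giving way to methyl in a number 0.61 log units higher from compound 1 to compound 2 (beyond the scatter); the new step shows that a lower number at this nitrogen does not depend on a ring, since an open chain also goes with a number beyond the scatter below compound 2. Nothing given here explains why the number falls.

The compounds shown leave open how the number changes with chain length, as only the methyl of compound 2 and the much longer chain of compound 4 are shown, with nothing of intermediate length such as ethyl or butyl. On these data alone, it also remains open whether a chain ending in a hydroxyl or an amine would follow the same course, and whether the ureido group of compound 3 would respond to the heptyl in the same way.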